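This account rests on a few compounds, and the source may have more. Where it says the series, first, only, none or still open, it means among the compounds named here.

Measured compounds:
compound 1 `O=C(CCCCCCc1ccccc1)c1ncc(-c2ccc(O)cc2)o1` — 140 nM
compound 2 `CN1CCN(C(=O)c2cnc(C(=O)CCCCCCc3ccccc3)o2)CC1` — 80 nM

Both were tested in an assay (Rattus norvegicus) for inhibition of Fatty-acid amide hydrolase 1 (Homo sapiens); on this read-out higher numbers stand for weaker inhibition and lower numbers for stronger inhibition. Compound 2 holds the lowest of the two numbers, but its nearest neighbour, compound 1, lies within the scatter of it: the step of a 1.8-fold lower number from compound 1 to compound 2 (0.24 log units; within the scatter) does not separate them.

Compound 3 `O=C(CCCCCCc1ccccc1)c1ncc(-c2cc(=O)[nH]c(=O)[nH]2)o1` keeps the core of compound 2 and changes one group: a group of 8 heavy atoms (4 carbon, 2 nitrogen, 2 oxygen; one six-membered aromatic ring with 2 hetero atoms) in place of a group of 9 heavy atoms (6 carbon, 2 nitrogen, 1 oxygen; one six-membered non-aromatic ring with 2 hetero atoms), on an aromatic carbon. Among the compounds with values here, no measured step covers this exact change. Within the data shown here, the only step at this position, from compound 1 to compound 2, swapped a six-membered aromatic ring bearing one hydrogen-bond donor for the piperazine amide and stayed within the scatter. Compound 3 brings back a six-membered aromatic ring at the same place, now with two donors and two acceptors. On that basis no step beyond the scatter is expected in this assay from compound 2 to compound 3, a 1.9-fold higher number from compound 2 to compound 3 (0.27 log units; within the scatter). Compound 3 is therefore estimated at 150 nM, with a likely range from 50 nM to 500 nM.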

Compound 3, inhibition constant: 12 nM
The estimate for compound 3 lay 13-fold (1.10 log units) above the measured number; measured number below the stated range.
By their numbers in this assay, from the lowest: compound 3; then compounds 2 and 1 (each within the scatter of the next).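

In this assay, this position on the five-membered aromatic ring can move the number beyond the scatter: the new ring, with its 2 hetero atoms, gives a 6.7-fold lower number from compound 2 to compound 3 (0.82 log units; beyond the scatter) against the (4-methylpiperazin-1-yl)carbonyl group and a 12-fold lower number from compound 1 to compound 3 (1.07 log units; beyond the scatter) against the 4-hydroxyphenyl group. A six-membered aromatic ring at this place is not enough on its own, as compound 1 also carries one and stays within the scatter of compound 2, so what counts here is the particular ring and what it bears. Nothing measured here accounts for this difference.

The compounds shown leave open whether the carbonyl groups or the ring nitrogen hydrogens of the new ring matter more. A plain pyridine ring or a carboxylic acid at this place would help separate those parts, and a shorter chain would test whether the effect holds elsewhere on the core.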